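The compounds below may be only part of what the source reports. "The series", "measured", "known", "first", "only" and "open" are said of these compounds alone.

Measured so far in a functional assay on MCF7 cells (Homo sapiens) for cytotoxicity, read by sulforhodamine B assay, with a stated time of 48 h; a lower number here means a stronger inhibitor, a higher number a weaker inhibitor:
- compound 1 `CCc1ccccc1OS(=O)(=O)c1ccc(NC(=O)NCCCCl)cc1`: 15000 nM
- compound 2 `CCCc1ccccc1OS(=O)(=O)c1ccc(NC(=O)NCCCCl)cc1`: 15000 nM
- compound 3 `O=C(NCCCCl)Nc1ccc(S(=O)(=O)Oc2ccc(O)cc2)cc1`: 51000 nM

Compound 1 and compound 2 share the lowest number of the three at 15000 nM, and the longer chain made no difference: no change at the digits printed from compound 1 to compound 2 (within the scatter). The next compound is compound 4 `CCCc1ccccc1OS(=O)(=O)c1ccc(NC(=O)NCC)cc1`, which differs from compound 2 at the other end of the molecule: hydrogen in place of chloromethyl on a saturated chain carbon, two bonds along the chain from an amide-type nitrogen. In words, hydrogen stands in place of chloromethyl on a saturated chain carbon, two bonds along the chain from an amide-type nitrogen, so that 3-chloropropyl becomes ethyl.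

Going by the values given here, no measured step touches this end, as compound 1, compound 2 and compound 3 all keep the 3-chloropropyl group. The only scale available comes from changes on the oxygen, namely a 3.4-fold higher number from compound 2 to compound 3 (0.53 log units; beyond the scatter) and a 3.4-fold higher number from compound 1 to compound 3 (0.53 log units; beyond the scatter). These are modest, and they bear on the new change only indirectly. A step of similar size towards a higher number in this assay is therefore a loose expectation, and a step within the scatter cannot be excluded. The estimated step is a 2.7-fold higher number from compound 2 to compound 4 (0.43 log units; beyond the scatter). For compound 4 the expected value is 40000 nM, with an estimated range of 15000 nM to 110000 nM.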

Compound 4, half-maximal inhibitory concentration: 1300 nM
Compound 4: the middle estimate sits 31-fold (1.49 log units) above what was measured, outside the stated range (below it).
By their numbers in this assay, from the lowest: compound 4; then compounds 1 and 2 (each within the scatter of the next); then compound 3.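

In this assay, the end of the molecule carrying the 3-chloropropyl group proves to be the more sensitive of the two sites varied so far: replacing chloromethyl with hydrogen on the saturated chain carbon gives a 12-fold lower number from compound 2 to compound 4 (1.06 log units; beyond the scatter), a larger step and in the opposite direction to the change on the oxygen, a 3.4-fold higher number from compound 2 to compound 3 (0.53 log units; beyond the scatter). In this matched pair, the chlorine-bearing chain is therefore not required for cytotoxicity, since the shorter ethyl group in compound 4 lowers the number rather than raising it, even though the 2-propylphenyl group stays unchanged. No available evidence accounts for the size or direction of this step.

The step changes chain length and removes chlorine at once, so the contribution of each remains unresolved; an unsubstituted propyl chain and a 2-chloroethyl chain would separate the two, while methyl or butyl would test how far chain length alone carries the trend. From the compounds shown here alone, it also remains open whether ethyl gives a similar step alongside 2-ethylphenyl or 4-hydroxyphenyl on the oxygen, and whether an amine or a carboxylic acid at the chain end would be tolerated.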